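Aryl swap on the fused core: toward compound 4

The compounds below may be only part of what the source reports. "The series", "measured", "known", "first", "only" and "open" are said of these compounds alone.

Three measured compounds share one core and differ only in the aryl group on it. Compound 1 `COc1cc(-c2ccnc3cc(-c4ccc(Cl)cc4)nn23)cc(OC)c1OC` gives 3340 nM in a functional assay on HCT-116 cells (Homo sapiens) for inhibition, read by CCK-8 assay, with a stated time of 48 h; a lower number here means a stronger inhibitor, a higher number a weaker inhibitor. Compound 3 `COc1ccc(-c2cc3nccc(-c4cc(OC)c(OC)c(OC)c4)n3n2)cc1F` gives 2840 nM in this assay, the lowest of the two numbers shown, with compound 1 nearest: the step of a 1.2-fold lower number from compound 1 to compound 3 (0.07 log units; within the scatter) stays within the scatter. Compound 2 `COc1cc(-c2ccnc3cc(-c4ccc(C(C)(C)C)cc4)nn23)cc(OC)c1OC` reaches only a limit of > 10000 nM in this assay. That value sits at the limit of > 10000 nM in this assay, at which 1 of the 3 values shown sits. From there the steps of an at least 2.9-fold higher number from compound 1 to compound 2 (0.47 log units; beyond the scatter) and an at least 3.5-fold lower number from compound 2 to compound 3 (0.54 log units; beyond the scatter) are both beyond the scatter.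

Compound 4 `COc1cc(-c2ccnc3cc(-c4ccc(N(C)C)cc4)nn23)cc(OC)c1OC` is unmeasured. The change (4-(dimethylamino)phenyl in place of 3-fluoro-4-methoxyphenyl on an aromatic carbon). The two aryl swaps measured so far bear on it: one within the scatter, one beyond it. Nothing shown points to a large shift for this particular group, so the step of a 1.2-fold higher number from compound 3 to compound 4 (0.09 log units; within the scatter) is expected to stay near the scatter. Compound 4 is estimated at 3500 nM, with a range from 1400 nM to 9000 nM.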

Compound 4, half-maximal inhibitory concentration: 2050 nM
Estimate against measurement, compound 4: 1.7-fold (0.23 log units) above; measured number inside the range.
By their numbers in this assay, from the lowest: compounds 4, 3 and 1 (each within the scatter of the next). At a limit, above all of these: compound 2.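

At this aromatic carbon of the five-membered ring, 4-(dimethylamino)phenyl gives no separation from either neighbouring aryl group, with a 1.4-fold lower number from compound 3 to compound 4 (0.14 log units; within the scatter) and a 1.6-fold lower number from compound 1 to compound 4 (0.21 log units; within the scatter) both within the scatter. A nitrogen-bearing group therefore joins chloro and the 3-fluoro-4-methoxyphenyl group in one band, and compound 2 goes against that band, with an at least 4.8-fold lower number from compound 2 to compound 4 (0.68 log units; beyond the scatter) beyond the scatter. The value of compound 2 remains a limit and not a number: the limit of > 10000 nM in this assay, at which 1 of the 4 values shown sits.

The compounds shown leave open whether a morpholine, a primary amine or a carboxylic acid in place of dimethylamino would stay in this band or leave it. Also open, from the compounds shown here alone, is how far the series moves when the trimethoxyphenyl group on the shared core is replaced, for example by a phenyl ring carrying a single methoxy group.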